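Biaryl sulfonamides: cytotoxicity on J774 cells, compound 4

The compounds below may be only part of what the source reports. "The series", "measured", "known", "first", "only" and "open" are said of these compounds alone.

Measured so far:
compound 1 `O=S(=O)(Nc1cccc(CO)c1)c1ccc(-c2ccc3[nH]ccc3c2)cc1` — > 5000 nM
compound 2 `CN(c1cccc(CO)c1)S(=O)(=O)c1ccc(-c2ccc(Cl)cc2Cl)cc1` — 2200 nM
compound 3 `O=S(=O)(Nc1ccc(-c2ccc(Cl)cc2Cl)cc1)c1cccc(CO)c1` — > 10000 nM

In a functional assay on J774 cells (Mus musculus) for cytotoxicity, read by resazurin assay, with a stated time of 72 h (on this read-out higher numbers stand for weaker inhibition and lower numbers for stronger inhibition), compound 1 gives > 5000 nM, which is a limit of the assay and not a number, sitting at the limit of > 5000 nM in this assay, at which 1 of the 3 values shown sits. Compound 3 also gives only a limit, > 10000 nM, at the limit of > 10000 nM in this assay, at which 1 of the 3 values shown sits. For the measured compounds named here, compound 2 is the one compound of the three with a number, 2200 nM. Going by the values given here, compound 1 thus stands among the weakly cytotoxic members; the two values of compound 1 and compound 2 show only a limit beside a number, and no step between them is given.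

Compound 4 `O=S(=O)(Nc1cccc(CO)c1)c1ccc(-c2ccccc2F)cc1` differs from compound 1 in one place: 2-fluorophenyl in place of 1H-indol-5-yl on an aromatic carbon, para to a large group. Among the compounds with values here, no measured step covers a change of this kind, so no direction is established. The expectation for the step from compound 1 to compound 4 is none beyond the scatter, a step that the limit leaves unreadable from compound 1 to compound 4. In this assay compound 4 is estimated at 7000 nM, with a range from 2000 nM to 25000 nM, and a limit rather than a number is the more likely report.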

Compound 4, half-maximal inhibitory concentration: 1300 nM
Compound 4: the middle estimate sits 5.4-fold (0.73 log units) above what was measured, outside the stated range (below it).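

In this assay, the group on this aromatic carbon, para to a large group, matters: 2-fluorophenyl in place of 1H-indol-5-yl gives an at least 3.8-fold lower number from compound 1 to compound 4 (0.58 log units; beyond the scatter). Compound 4 also shows that the core of compound 1 can give a measured number for cytotoxicity and not only a limit. The true size of the step cannot be read, because compound 1 is reported only as a limit: the limit of > 5000 nM in this assay, at which 1 of the 4 values shown sits.

With one pair covering this place, the compounds shown do not separate the entry of the fluorine from the loss of the five-membered aromatic ring and its hydrogen-bond donor. They also leave open how an unsubstituted phenyl, or a phenyl carrying an amine or a carboxylic acid, would read at this place.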